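Acyl variation on the amide of an aminophenyl ketone series

This account rests on a few compounds, and the source may have more. Where it says the series, first, only, none or still open, it means among the compounds named here.

Measured so far in a functional assay for inhibition of kynurenine 3-monooxygenase (Rattus norvegicus), tested at 1 mM; on this read-out higher numbers stand for more inhibition at the one concentration tested (going by the name of the read-out) and lower numbers for less inhibition:
compound 1 `COc1ccc(N)c(C(=O)CCNC(=O)C2CC2)c1` gives 99.9%
compound 2 `COc1ccc(N)c(C(=O)CCNC(=O)C2CCCCC2)c1` gives 99.6%
compound 3 `COc1ccc(N)c(C(=O)CCNC(C)=O)c1` gives 102%

Compound 3 has the highest number of the three, yet both gaps to it are within the scatter: a number 2.1 percentage points higher from compound 1 to compound 3 (within the scatter) and a number 2.4 percentage points higher from compound 2 to compound 3 (within the scatter). The numbers of the three measured compounds are level with one another at the single concentration tested.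

Compound 4 `CCCCC(=O)NCCC(=O)c1cc(OC)ccc1N` is not yet measured. The change from compound 3 is propyl in place of hydrogen on a saturated chain carbon bound to a carbonyl carbon. The two steps that bear on it are the exchanges of the group on the carbonyl carbon, a number 2.1 percentage points higher from compound 1 to compound 3 (within the scatter) and a number 2.4 percentage points higher from compound 2 to compound 3 (within the scatter), neither of which moved the read-out beyond the scatter. The same is therefore expected here: an estimated a number 2 percentage points lower from compound 3 to compound 4 (within the scatter), with compound 4 expected at 100%, between 92% and 104%.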

Compound 4, a percentage reported as inhibition, at one concentration (the size of the read-out at that concentration, not a potency): 97.2%
Estimate against measurement, compound 4: 2.8 percentage points above; measured number inside the range.
By their numbers in this assay, from the lowest: compounds 4, 2, 1 and 3 (each within the scatter of the next).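

In this assay the open butyl chain on the carbonyl carbon gives a number 4.8 percentage points lower from compound 3 to compound 4 (within the scatter), a number 2.4 percentage points lower from compound 2 to compound 4 (within the scatter) and a number 2.7 percentage points lower from compound 1 to compound 4 (within the scatter). An unbranched chain of this length therefore stays level with methyl, cyclopropyl and cyclohexyl at this position, and none of the four groups separates from the others at the single concentration tested. No data on hand bear on this result.

As far as these compounds go, a carboxylic acid or an amine at the end of the chain remains open. Any difference in potency among the four compounds also remains open.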